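The source may report more compounds than this note shows. Statements on the series, on what has been measured and on what is new or still open speak of the compounds shown alone.

Measured compounds:
- Compound 1, `COc1ccc(-c2nc3cccc(-c4cc(OC)c(OC)c(OC)c4)c3o2)cc1`. In a functional assay on U-251 cells (Homo sapiens) for antiproliferative activity, read by MTT assay, with a stated time of 48 h (on this read-out lower numbers stand for stronger inhibition and higher numbers for weaker inhibition), compound 1 gives > 25000 nM, which is a limit of the assay and not a number.
- Compound 2, `COc1cccc(-c2nc3cccc(-c4cc(OC)c(OC)c(OC)c4)c3o2)c1`. In this assay compound 2 gives > 25000 nM, again a limit of the assay.
- Compound 3, `COc1cc(-c2cccc3nc(-c4cccc(Cl)c4)oc23)cc(OC)c1OC`. In this assay compound 3 gives 18500 nM.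

Compound 1 thus stands only as a limit, and so does compound 2; of the three values shown, only compound 3 is a number (the limit of > 25000 nM in this assay, at which 2 of the 3 values shown sit). The step that the two limits leave unreadable from compound 1 to compound 2 cannot be read from two limits.

Compound 4, `COc1cc(-c2cccc3nc(-c4ccc(Cl)cc4)oc23)cc(OC)c1OC`, is not yet measured. It differs from compound 1 by chloro in place of methoxy on an aromatic carbon. Going by the values given here, two measured steps bear on this. The step of an at least 1.3-fold lower number from compound 1 to compound 3 (0.13 log units; that floor lies within the scatter) carries the chloro in with a change of position as well; the step of an at least 1.3-fold lower number from compound 2 to compound 3 (0.13 log units; that floor lies within the scatter) is the same chloro in place of methoxy on an aromatic carbon, though on the 3-methoxyphenyl of compound 2. Both steps read as a lower number from a limit, with a floor that lies within the scatter, so no more than a small gain is expected.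

For compound 4 the expected step is an at least 1.2-fold lower number from compound 1 to compound 4 (0.09 log units; that floor lies within the scatter). Compound 4 is estimated at 20000 nM, with a range from 8000 nM to 50000 nM, and a fair chance that only a limit is reported.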

Compound 4, half-maximal inhibitory concentration: 1600 nM
Compound 4: the middle estimate sits 13-fold (1.10 log units) above what was measured; the whole stated range lies above it.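

In this assay the 4-chlorophenyl brings a step beyond the scatter that the 3-chlorophenyl of compound 3 did not show, with an at least 15-fold lower number from compound 1 to compound 4 (1.19 log units; beyond the scatter) and an at least 15-fold lower number from compound 2 to compound 4 (1.19 log units; beyond the scatter), both read from a limit. The place of the chloro on the phenyl ring therefore matters here, since 4-chlorophenyl in place of 3-chlorophenyl gives a 12-fold lower number from compound 3 to compound 4 (1.06 log units; beyond the scatter). Chloro in place of methoxy thus has no single size across the compounds shown: the same change on two cores in this assay, an at least 1.3-fold lower number (0.13 log units; that floor lies within the scatter) from compound 2 to compound 3 and an at least 15-fold lower number (1.19 log units; beyond the scatter) from compound 1 to compound 4; the limit leaves it open whether they differ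

From the compounds shown here alone, whether the gain belongs to chloro itself or would also come with another group at that place, such as bromo, trifluoromethyl or an amine, stays open. Also open is whether the trimethoxyphenyl part of the core is needed for this gain, as all the compounds shown carry it unchanged.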